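The source may report more compounds than this note shows. Statements on the series, on what has been measured and on what is new or still open speak of the compounds shown alone.

Measured so far:
Compound 1 `OC[C@H]1O[C@@H](n2cnc3c(NCc4ccc(Br)cc4)ncnc32)[C@H](O)[C@@H]1O`, tested in a functional assay on G-361 cells (Homo sapiens) for antiproliferative activity, with a stated time of 72 h (a lower number here means a stronger inhibitor, a higher number a weaker inhibitor), gives > 166000 nM, which is a limit of the assay and not a number.
Compound 2 `COc1cccc(CNc2ncnc3c2ncn3[C@@H]2O[C@H](CO)[C@@H](O)[C@H]2O)c1OC` has no result in this assay: "not determined" (no result reported).
Compound 3 `OC[C@H]1O[C@@H](n2cnc3c(NCc4ccc(F)c(F)c4F)ncnc32)[C@H](O)[C@@H]1O` gives > 166000 nM in this assay, again only a limit.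
Compound 4 `OC[C@H]1O[C@@H](n2cnc3c(NCc4ccccc4OC(F)F)ncnc32)[C@H](O)[C@@H]1O` has not yet been measured.

Compound 1 therefore stands on a limit, not on a measured number, and the picture around it is thin: of the three entries in this assay, two sit at the limit of > 166000 nM in this assay, at which 2 of the 3 values shown sit, and the third carries no number at all.

Going by the values given here, the path to compound 4 changes only one part of compound 1: 2-(difluoromethoxy)phenyl in place of 4-bromophenyl on a saturated chain carbon bound to a nitrogen on an aromatic ring.

Among the compounds with values here, only one pair with both ends measured differs in a single place, and that is a step that the two limits leave unreadable from compound 1 to compound 3, where both ends are limits, so the size of the step cannot be read. Within the data shown here, there is thus no measured step that shows what swapping the group on this carbon does to potency, in either direction.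

With both neighbours of compound 4 at the limit, the step from compound 1 to compound 4 is expected to be a step that the limit leaves unreadable from compound 1 to compound 4, meaning no reading beyond the limit. Compound 4 is accordingly estimated at 200000 nM, within a range of 50000 nM to 800000 nM, and most likely the assay will again report only a limit.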

Compound 4, half-maximal inhibitory concentration: > 166000 nM
Compound 4: a limit, no number (the forecaster's own chance of this, stated with the estimate: 75%); the middle value lies beyond the limit too.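

Going by these compounds alone, compound 1, compound 3 and compound 4 all stop at a limit of this assay, not at a number, so no step among them can be read in size. The compounds shown leave open whether any group on this saturated chain carbon can give a measurable potency, with the results so far gathered at one point: the limit of > 166000 nM in this assay, at which 3 of the 4 values shown sit.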